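The source may report more compounds than this note shows. Statements on the series, on what has been measured and on what is new or still open speak of the compounds shown alone.

Among the compounds with values here, compound 2 `Cc1cccc(Cn2cnc3c(N(C)C)ncnc32)c1` gives 25 mg/kg in a functional assay on the whole organism with Rattus norvegicus as the target, in the maximal electroshock model (on this read-out higher numbers stand for an effect only at larger amounts of compound and lower numbers for an effect already at smaller amounts), the highest of the two numbers measured so far. Its nearest neighbour is compound 1 `CN(C)c1ncnc2c1ncn2Cc1cccc(Br)c1`, which gives 13 mg/kg in this assay, and the step of a 1.9-fold higher number from compound 1 to compound 2 (0.28 log units; within the scatter) lies within the scatter. Compound 3 `COc1cccc(Cn2cnc3c(N(C)C)ncnc32)c1` differs from compound 2 by methoxy in place of methyl on an aromatic carbon. Within the data shown here, no measured step exchanges methyl for methoxy, and the one step available, bromo to methyl, stayed within the scatter, so a step of no change at the digits printed from compound 2 to compound 3 (within the scatter) is expected, nothing beyond the scatter in either direction. Compound 3 is therefore estimated at 25 mg/kg, with a range from 12 mg/kg to 50 mg/kg.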

Compound 3, dose for half-maximal effect: 12.5 mg/kg
The estimate for compound 3 lay 2.0-fold (0.30 log units) above the measured number; the measured number falls inside the stated range.
By their numbers in this assay, from the lowest: compounds 3, 1 and 2 (each within the scatter of the next).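

In this assay, methoxy in place of methyl gives a 2.0-fold lower number from compound 2 to compound 3 (0.30 log units; within the scatter) and methoxy in place of bromo gives a 1.0-fold lower number from compound 1 to compound 3 (0.02 log units; within the scatter) at this aromatic carbon, meta to a large group. The position thus accepts a group with an oxygen and a hydrogen-bond acceptor, and none of the three groups shown stands beyond the scatter from the others. Nothing available bears on the cause of these numbers. The compounds shown leave open whether an amine or a carboxylic acid here would shift the number beyond the scatter. They also leave open what a longer chain in place of methoxy would do.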